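Swapping the aryl on the ring nitrogen of compound 2

The source may hold more compounds than are shown below. What is called first, only, known or untested is meant among the compounds shown, and "the series" means these compounds.

Compound 2 `Cc1cc(=O)n(-c2ccc(Br)cc2F)nc1C(=O)Nc1ccc(Oc2ncnc3sccc23)c(F)c1` is the weaker of the two measured compounds in a functional assay on HepG2 cells (Homo sapiens) for cytotoxicity, read by MTT assay, with a stated time of 72 h (a lower number here means a stronger inhibitor, a higher number a weaker inhibitor), where compound 2 gives 13800 nM. Going by the values given here, its only neighbour is compound 1 `Cc1cc(=O)n(-c2ccc(Br)cc2F)nc1C(=O)Nc1ccc(Oc2ncnc3sccc23)cc1`, which in this assay gives 6300 nM; the step between them, a 2.2-fold higher number from compound 1 to compound 2 (0.34 log units; beyond the scatter), places compound 2 at the higher end of the pair, and that step concerns the anilide ring, not the aryl on the ring nitrogen.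

Compound 3 `Cc1cc(=O)n(-c2ccc(F)c(F)c2)nc1C(=O)Nc1ccc(Oc2ncnc3sccc23)c(F)c1` differs from compound 2 at that other site: 3,4-difluorophenyl in place of 4-bromo-2-fluorophenyl on an aromatic nitrogen. Among the compounds with values here, no measured step touches this position, so there is nothing in the data that directly bears on the exchange; the one measured step, a 2.2-fold higher number from compound 1 to compound 2 (0.34 log units; beyond the scatter), speaks only to a change elsewhere and was modest.

On that basis the expectation for the step from compound 2 to compound 3 in this assay is a 1.2-fold lower number from compound 2 to compound 3 (0.06 log units; within the scatter), that is, no step beyond the scatter in either direction. Compound 3 is therefore estimated to give 12000 nM in this assay, with a range from 4000 nM to 40000 nM.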

Compound 3, half-maximal inhibitory concentration: > 40000 nM
Compound 3: a limit, no number; the forecaster's own chance of this, stated with the estimate: 15%; at least 3.3-fold (0.52 log units) between middle value and limit.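

In this assay, the exchange of 4-bromo-2-fluorophenyl for 3,4-difluorophenyl on the aromatic nitrogen gives an at least 2.8-fold higher number from compound 2 to compound 3 (0.46 log units; beyond the scatter), so the aryl on the ring nitrogen is a site where a change of substituents moves the read-out beyond the scatter. Going by these compounds alone, the earlier pair could not show this, as its only step, a 2.2-fold higher number from compound 1 to compound 2 (0.34 log units; beyond the scatter), lies on the anilide ring. Compound 3 gives a limit of the assay and not a number, so the step has a lower bound but no known upper end: the limit of > 40000 nM in this assay, at which 1 of the 3 values shown sits.

The two aryl groups differ both in their halogens and in where these stand, so this single exchange does not separate the loss of the bromine from the new placing of the fluorines. The compounds shown also leave open how a plain phenyl, a 4-methoxyphenyl or a pyridyl group would behave on this nitrogen, and whether the 3,4-difluorophenyl exchange would give a similar step on the core of compound 1.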